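From 4-fluorobenzyl to 4-bromobenzyl in compound 3

The source may hold more compounds than are shown below. What is called first, only, known or untested is meant among the compounds shown, and "the series" means these compounds.

In a functional assay on HeLa cells (Homo sapiens) for antiproliferative activity, read by MTT assay, with a stated time of 24 h (a lower number here means a stronger inhibitor, a higher number a weaker inhibitor), compound 1 (`Cc1ccccc1CSc1nnc(-c2ccc3c(c2)OCCO3)n1-c1ccccc1`) gives 36000 nM and compound 2 (`Fc1ccc(CSc2nnc(-c3ccc4c(c3)OCCO4)n2-c2ccccc2)cc1`) gives 46900 nM on the same shared core. The two values lie within the scatter of each other, so compound 2 stands level with compound 1 on the numbers available.

Compound 3 (`Brc1ccc(CSc2nnc(-c3ccc4c(c3)OCCO4)n2-c2ccccc2)cc1`) differs from compound 2 by bromo in place of fluoro on an aromatic carbon and so has bromo in place of fluoro on an aromatic carbon, para to a large group. Among the compounds with values here, only one measured step bears on this change: a 1.3-fold higher number from compound 1 to compound 2 (0.11 log units; within the scatter) for 4-fluorophenyl in place of 2-methylphenyl at the same saturated chain carbon bound to a sulfur. That step alters the same group but does not exchange one halogen for another, so it is only a loose guide. Within the data shown here, no measured pair tests bromo directly.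

The expected change is a 1.1-fold lower number from compound 2 to compound 3 (0.05 log units; within the scatter) and no step beyond the scatter is expected in either direction. Compound 3 is estimated in this assay at 42000 nM with a range from 19000 nM to 90000 nM as the expected bounds.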

Compound 3, half-maximal inhibitory concentration: 54600 nM
For compound 3 the middle estimate is 1.3-fold (0.11 log units) below the measured one; low and high end bracket the measured number.
By their numbers in this assay, from the lowest: compounds 1, 2 and 3 (each within the scatter of the next).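

In this assay, within the data shown here, the exchange of one halogen for another at this aromatic carbon, para to a large group, gives a 1.2-fold higher number from compound 2 to compound 3 (0.07 log units; within the scatter) and thus provides the first direct reading on bromo against fluoro. Taking the comparison back to the 2-methylphenyl group gives a 1.5-fold higher number from compound 1 to compound 3 (0.18 log units; within the scatter) for the 4-bromophenyl group on the saturated chain carbon bound to a sulfur, so this wider change also stays inside the scatter and compounds 1, 2 and 3 stand level on the numbers available. No accompanying measurement offers an explanation for this flat reading.

On these data alone, the three compounds cover only fluoro, bromo and a methyl-bearing phenyl group, so it remains open whether an amine, a carboxylic acid or a longer chain on this aromatic ring would give a step beyond the scatter. As far as these compounds go, it is also open whether the level reading seen with these groups would hold on a shared core altered elsewhere, for example with a methoxy group in place of the phenyl group on the core nitrogen.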